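Amino in Place of Methoxy on a Triazine Core

The source may report more compounds than this note shows. Statements on the series, on what has been measured and on what is new or still open speak of the compounds shown alone.

Compound 1 `COc1ncnc(Nc2ccc(Cl)c(OCC=C(C)C)c2)n1` gives 18000 nM in an ADME assay on MT2 cells (Homo sapiens) for cytotoxicity; a lower number here means that less compound is tolerated, a higher number that more compound is tolerated. Compound 2 `CC(C)=CCOc1cc(Nc2ncnc(N)n2)ccc1Cl` gives 48000 nM. Compound 3 `COc1nc(Nc2ccc(C#N)c(OCC=C(C)C)c2)nc(OC)n1` reaches only a limit, > 100000 nM.

The step of a 2.7-fold higher number from compound 1 to compound 2 (0.43 log units; beyond the scatter) is made by the change (amino in place of methoxy on an aromatic carbon). The difference between the core of compound 1 and the core of compound 3 is not broken down here. Compound 4 `COc1nc(N)nc(Nc2ccc(C#N)c(OCC=C(C)C)c2)n1` differs from compound 3 by the same kind of change, (amino in place of methoxy on an aromatic carbon), though here the place is also meta to a methoxy group (2 heavy atoms). Since compound 3 already sits at the limit of > 100000 nM in this assay, at which 1 of the 3 values shown sits, and the earlier step only raised the tolerated concentration, compound 4 is expected to remain at or beyond that limit, a step that the limit leaves unreadable from compound 3 to compound 4. The estimate for compound 4 is 150000 nM, between 80000 nM and 300000 nM.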

Compound 4, half-maximal cytotoxic concentration: 110 nM
Compound 4: middle estimate off by 1400-fold (3.13 log units), on the high side; the measured number lies below the stated range.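

In this assay, amino in place of methoxy gives an at least 900-fold lower number from compound 3 to compound 4 (2.95 log units; beyond the scatter), and the change does not carry over from one core to another in this series in either size or direction: the same change on two cores in this assay, a 2.7-fold higher number (0.43 log units; beyond the scatter) from compound 1 to compound 2 and an at least 900-fold lower number (2.95 log units; beyond the scatter) from compound 3 to compound 4, at least 2400-fold (3.38 log units) apart, beyond the scatter of two such steps

Compound 3 stands at > 100000 nM, which is a limit of the assay and not a number.

With only these two pairs, the result does not show which feature of the cores decides the direction of the step.

Left open is how a methylamino group or a hydroxyl group in the same place would read. Also open, on these data alone, is whether the nitrile or the remaining methoxy group of compound 4 goes with its low value.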